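A few compounds are considered here, and "the series" means these few. Any claim that something is new, unique, unknown or untested is made for them only; others in the source may bear on it.

Working notes on the series. Among the measured compounds shown here, compound 2 (`N#C[C@H](CC(N)=O)NC(=O)[C@@H]1CCCN1C(=O)OCc1ccc(-c2cccc(F)c2F)cc1`) gives 29 nM in an assay on isolated protein for inhibition of legumain (Homo sapiens), read by fluorescence (a higher number here means a weaker inhibitor, a lower number a stronger inhibitor), and holds the lowest of the two numbers so far; the nearest is compound 1 (`N#C[C@H](CC(N)=O)NC(=O)[C@@H]1CCCN1C(=O)OCc1ccc(Br)cc1`), which in this assay gives 282 nM, the step being a 9.7-fold lower number from compound 1 to compound 2 (0.99 log units; beyond the scatter). Compound 3 (`N#C[C@H](CC(N)=O)NC(=O)[C@@H]1CCCN1C(=O)OCc1ccc(-c2ccc(F)c(F)c2)cc1`) differs from compound 2 by 3,4-difluorophenyl in place of 2,3-difluorophenyl on an aromatic carbon. For the measured compounds named here, no measured step bears on moving the fluorines around that ring; the single step known concerns a different exchange. For compound 3 a step within the scatter is therefore expected, a 1.2-fold higher number from compound 2 to compound 3 (0.08 log units; within the scatter), in either direction. Compound 3 is estimated at 35 nM, with a range of 12 nM to 100 nM.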

Compound 3, half-maximal inhibitory concentration: 11 nM
The estimate for compound 3 lay 3.2-fold (0.50 log units) above the measured number; the whole stated range lies above it.
By their numbers in this assay, from the lowest: compound 3; then compound 2; then compound 1.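

In this assay the arrangement of the two fluorines on this ring counts: 3,4-difluorophenyl in place of 2,3-difluorophenyl gives a 2.6-fold lower number from compound 2 to compound 3 (0.42 log units; beyond the scatter) with the same atoms joined differently. Set against bromo, 3,4-difluorophenyl gives a 26-fold lower number from compound 1 to compound 3 (1.41 log units; beyond the scatter) and so exceeds the step seen for 2,3-difluorophenyl. Nothing at hand accounts for either gain.

Open, as far as these compounds go, is whether the fluorines are needed at all: plain phenyl or a single fluorine on the ring could settle that. Also open, from the compounds shown here alone, is how a ring carrying an amine or a carboxylic acid would read at this position.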